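A few compounds are considered here, and "the series" means these few. Any claim that something is new, unique, unknown or untested is made for them only; others in the source may bear on it.

Three compounds share one core and differ only in one group on an aromatic carbon. Compound 1 `COc1cc(-c2nccn3cc(-c4ccc(C(F)(F)F)cc4)nc23)cc(OC)c1OC` carries trifluoromethyl, compound 2 `COc1cc(-c2nccn3cc(-c4ccc(N)cc4)nc23)cc(OC)c1OC` amino, compound 3 `COc1cc(-c2nccn3cc(-c4ccc(F)cc4)nc23)cc(OC)c1OC` fluoro. In a functional assay on HCT-116 cells (Homo sapiens) for inhibition, read by MTT assay, with a stated time of 48 h (on this read-out higher numbers stand for weaker inhibition and lower numbers for stronger inhibition), compound 1 reaches only the assay limit, > 10000 nM. In this assay compound 2 gives 158 nM and compound 3 gives 263 nM, and the two are not separable, as a 1.7-fold higher number from compound 2 to compound 3 (0.22 log units; within the scatter). The moves away from trifluoromethyl were large: an at least 63-fold lower number from compound 1 to compound 2 (1.80 log units; beyond the scatter) and an at least 38-fold lower number from compound 1 to compound 3 (1.58 log units; beyond the scatter). Compound 4 `COc1cc(-c2nccn3cc(-c4ccc([N+](=O)[O-])cc4)nc23)cc(OC)c1OC` is the next step, (nitro in place of fluoro on an aromatic carbon). Only those two large steps bear on it, and a nitro at the same place could sit with either side. The expected outcome for compound 4 is a 1.5-fold higher number from compound 3 to compound 4 (0.18 log units; within the scatter), an estimate of 400 nM in a range from 100 nM to 5000 nM.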

Compound 4, half-maximal inhibitory concentration: > 10000 nM
Compound 4: no number, only a limit; the forecaster's own chance of this, stated with the estimate: 15%; middle value at least 25-fold (1.39 log units) away from the limit.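

In this assay, the group on this aromatic carbon now separates sharply for a second time, with nitro falling on the trifluoromethyl side: an at least 38-fold higher number from compound 3 to compound 4 (1.58 log units; beyond the scatter), and an at least 63-fold higher number from compound 2 to compound 4 (1.80 log units; beyond the scatter). Among the four compounds, amino and fluoro give measurable values, while nitro and trifluoromethyl reach only a limit of the assay: the limit of > 10000 nM in this assay, at which 2 of the 4 values shown sit. The step between compound 1 and compound 4 cannot be read, as both values are limits.

Going by these compounds, how far either compound lies past that limit stays open. Also open, on these data alone, is which side a hydroxyl, a methoxy or a nitrile at this place would join.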